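A few compounds are considered here, and "the series" means these few. Any claim that something is new, unique, unknown or untested is made for them only; others in the source may bear on it.

Compound 2 `CN(C)c1ccc(C(=O)NCc2ccc(NS(C)(=O)=O)cc2Cl)cc1` has the highest of the three numbers in an ADME assay on microsomes from liver (Rattus norvegicus, strain Sprague-Dawley) for metabolic stability, read by HPLC, using NADPH, with stated times of 5 min and 60 min, tested at 10 uM (a higher number here means faster removal of the compound, a lower number slower removal), where compound 2 gives 25 mL.min-1.g-1. Compound 1 `CC(C)(C)c1ccc(C(=O)NCc2ccc(NS(=O)(=O)C(F)(F)F)cc2Cl)cc1` gives 17 mL.min-1.g-1 in this assay, and compound 3 `CS(=O)(=O)Nc1ccc(CNC(=O)c2ccc(N3CCCC3)cc2)c(Cl)c1` gives 17 mL.min-1.g-1; both gaps to compound 2 are within the scatter, so the three compounds cannot really be told apart on these numbers. Compound 4 `CS(=O)(=O)Nc1ccc(CNC(=O)c2ccc(C(F)(F)C(F)(F)F)cc2)c(Cl)c1` has not yet been measured. It differs from compound 2 in one place: 1,1,2,2,2-pentafluoroethyl in place of dimethylamino on an aromatic carbon. Going by the values given here, the only measured step at that same spot, a 1.5-fold lower number from compound 2 to compound 3 (0.17 log units; within the scatter), changed nothing beyond the scatter, but it swapped one nitrogen-bearing group for another, whereas the entering group here carries fluorine and no nitrogen; no measured pair shows a change of that kind. Compound 1 also lacks a nitrogen at that spot, yet it differs from compound 2 in a second place too, so its value only shows that such a compound can sit close to compound 2. Resting on the step of a 1.5-fold lower number from compound 2 to compound 3 (0.17 log units; within the scatter) alone, compound 4 is expected to show a step of a 1.8-fold lower number from compound 2 to compound 4 (0.25 log units; within the scatter), within the scatter. Compound 4 is estimated at 14 mL.min-1.g-1, with a range from 5 mL.min-1.g-1 to 40 mL.min-1.g-1.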

Compound 4, intrinsic clearance in microsomes: 14 mL.min-1.g-1
For compound 4 middle estimate and measured number coincide at the digits printed, within the range that was stated.
By their numbers in this assay, from the lowest: compounds 4, 1, 3 and 2 (each within the scatter of the next).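

In this assay, putting 1,1,2,2,2-pentafluoroethyl in place of dimethylamino gives a 1.8-fold lower number from compound 2 to compound 4 (0.25 log units; within the scatter) and putting it in place of pyrrolidin-1-yl gives a 1.2-fold lower number from compound 3 to compound 4 (0.08 log units; within the scatter) at the same spot. Going by these compounds alone, both steps lie within the scatter, so this is the first single-place change to show that, on an aromatic carbon para to a large group, a fluorine-bearing group without nitrogen cannot be told apart from either nitrogen-bearing group in this read-out. Nothing measured here offers a reason for this closeness.

The compounds shown leave open whether the same holds for very different groups at this spot, such as a carboxylic acid, a primary amine or a longer fluorinated chain. They also leave open how a bare hydrogen there would compare with these groups.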